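The source may report more compounds than this note shows. Statements on the series, on what has been measured and on what is new or still open speak of the compounds shown alone.

Working notes on the series.

Three compounds of the shared core have numbers in a functional assay on MGC-803 cells (Homo sapiens) for inhibition, read by MTT assay, with a stated time of 72 h; a lower number here means a stronger inhibitor, a higher number a weaker inhibitor. Compound 1, `O=C(OCc1ccccc1)N1CCN(C(=S)SCc2cn(Cc3ccc(Cl)cc3)nn2)CC1`, gives 31300 nM and stands highest of the three. Compound 2, `CC(C)(C)OC(=O)N1CCN(C(=S)SCc2cn(Cc3cc(=O)oc4cc(O)ccc34)nn2)CC1`, gives 4960 nM in this assay, and compound 3, `Cc1ccc(Cn2cc(CSC(=S)N3CCN(C(=O)OC(C)(C)C)CC3)nn2)cc1`, gives 3490 nM; the two values show compound 1 to be the weakest of the measured set, its gap to each of the other two being beyond the scatter. Within the data shown here, no step between two measured compounds that differ in a single place is available, so the effect of any one change is not known from the measured compounds themselves.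

Compound 4, `O=C(OCc1ccccc1)N1CCN(C(=S)SCc2cn(Cc3ccc(F)cc3)nn2)CC1`, is not yet measured in this assay. It differs from compound 1 by fluoro in place of chloro on an aromatic carbon, which leaves the rest of the molecule untouched. With nothing in the measured set that separates this change, the expectation is a step from compound 1 to compound 4 of about none beyond the scatter, a 1.2-fold higher number from compound 1 to compound 4 (0.08 log units; within the scatter), and a value for compound 4 estimated at 38000 nM, within a range from 14000 nM to 100000 nM.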

Compound 4, half-maximal inhibitory concentration: 17600 nM
The estimate for compound 4 lay 2.2-fold (0.33 log units) above the measured number; the range from low to high includes it.
By their numbers in this assay, from the lowest: compounds 3 and 2 (each within the scatter of the next); then compounds 4 and 1 (each within the scatter of the next).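

Among these compounds, the only single-place step, fluoro in place of chloro on an aromatic carbon para to a large group, reads in this assay as a 1.8-fold lower number from compound 1 to compound 4 (0.25 log units; within the scatter) and so does not separate the two compounds. Among the compounds shown here, at this position of the shared core, the 4-chlorobenzyl and 4-fluorobenzyl forms therefore cannot be told apart by this read-out, which the earlier compounds, differing in more than one place, could not show. Nothing at hand bears on what lies behind this reading.

From the compounds shown here alone, whether this position responds to anything other than these two groups stays open, since a methoxy group, a nitrile or an amine in the same place would test a different kind of substituent. Also open, going by these compounds, is whether the same change reads alike on the other compounds.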